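Amide chain extension on a shared core

A few compounds are considered here, and "the series" means these few. Any claim that something is new, unique, unknown or untested is made for them only; others in the source may bear on it.

Measured so far:
compound 1, `COCCNC(=O)C1CCN(c2nc(N)c3cc(OC)c(OC)cc3n2)CC1`, in an assay on isolated protein for displacement of a labelled ligand from Adrenergic receptor alpha-1 (Rattus norvegicus); on this read-out higher numbers stand for weaker inhibition and lower numbers for stronger inhibition: 1.13 nM
compound 2, `CCCNC(=O)CC1CCN(c2nc(N)c3cc(OC)c(OC)cc3n2)CC1`, in this assay: 0.65 nM

Compound 2 stands at the lowest of the two measured numbers, with compound 1 nearest. Within the data shown here, the only measured step, a 1.7-fold lower number from compound 1 to compound 2 (0.24 log units; within the scatter), lies within the scatter, so the two measured compounds cannot be placed in order on this assay.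

Compound 3, `CCCCNC(=O)CC1CCN(c2nc(N)c3cc(OC)c(OC)cc3n2)CC1`, differs from compound 2 by methyl in place of hydrogen on a saturated chain carbon, three bonds along the chain from an amide-type nitrogen. Among the measured compounds shown here, no measured pair shares this change. For the measured compounds named here, the single measured step, a 1.7-fold lower number from compound 1 to compound 2 (0.24 log units; within the scatter), alters the amide side in another way and stays within the scatter, and it is the only evidence bearing on the new step. Nothing in the measured pairs points to a shift in this assay. The expected step is therefore a 1.1-fold higher number from compound 2 to compound 3 (0.03 log units; within the scatter), not beyond the scatter. Compound 3 is estimated at 0.7 nM in this assay, with a range from 0.3 nM to 1.6 nM.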

Compound 3, inhibition constant: 1.4 nM
Compound 3: middle estimate off by 2.0-fold (0.30 log units), on the low side; low and high end bracket the measured number.
By their numbers in this assay, from the lowest: compounds 2, 1 and 3 (each within the scatter of the next, the first and the last beyond it).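

In this assay, among these compounds, the saturated chain carbon three bonds along the chain from an amide-type nitrogen proves sensitive to a single methyl: the change from propyl to butyl gives the first step beyond the scatter, though a modest one (for the numbers, a 2.2-fold higher number from compound 2 to compound 3 (0.33 log units; beyond the scatter)). The other new step stays within the scatter (a 1.2-fold higher number from compound 1 to compound 3 (0.09 log units; within the scatter)), so the (butylcarbamoyl)methyl and (2-methoxyethyl)carbamoyl groups cannot be placed in order on this read-out. No available evidence bears on the propyl to butyl step.

This single pair does not show whether a pentyl chain would move the number further in the same direction. Also open, going by these compounds, is how an amine or a carboxylic acid at the end of the chain would compare with propyl and butyl.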